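The source may hold more compounds than are shown below. What is called first, only, known or untested is meant among the compounds shown, and "the series" means these compounds.

Working notes on the shared core. Compound 1 `CCCN(CCC)c1c(C)nc(-c2c(C)cc(C)cc2OC)nc1OC` gives 15 nM in an in vitro assay on IMR-32 cells for displacement of a labelled ligand from corticotropin-releasing factor receptor 1 (Homo sapiens); on this read-out higher numbers stand for weaker inhibition and lower numbers for stronger inhibition. Compound 2 `CCCN(CCC)c1c(CC)nc(-c2c(C)cc(C)cc2OC)nc1OC` differs from compound 1 by methyl in place of hydrogen on a saturated chain carbon bound to an aromatic carbon; in this assay compound 2 gives 22 nM, a step of a 1.5-fold higher number from compound 1 to compound 2 (0.17 log units; within the scatter). Compound 3 `CCCN(CCC)c1c(CC(C)O)nc(-c2c(C)cc(C)cc2OC)nc1OC` differs from compound 1 by 1-hydroxyethyl in place of hydrogen on a saturated chain carbon bound to an aromatic carbon; in this assay compound 3 gives 1150 nM, the highest number of the three and beyond the scatter from both others.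

Compound 4 `CCCN(CCC)c1c(CC(C)(C)O)nc(-c2c(C)cc(C)cc2OC)nc1OC` is not yet measured. It differs from compound 3 by methyl in place of hydrogen on a saturated chain carbon bound to an oxygen on a saturated carbon and two saturated chain carbons. This is the same kind of change as from compound 1 to compound 2, though the place differs: there the carbon is bound to an aromatic carbon, here to an oxygen on a saturated carbon and two saturated chain carbons. A similarly small step is expected on compound 3 because the earlier one was a 1.5-fold higher number from compound 1 to compound 2 (0.17 log units; within the scatter). The expected step is a 1.3-fold higher number from compound 3 to compound 4 (0.12 log units; within the scatter). Compound 4 is thus estimated at 1500 nM, likely between 500 nM and 4500 nM.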

Compound 4, inhibition constant: 604 nM
For compound 4 the middle estimate is 2.5-fold (0.40 log units) above the measured one; measured number inside the range.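

In this assay, methyl in place of hydrogen does not carry over as one fixed step between these two cores: the same change on two cores in this assay, a 1.5-fold higher number (0.17 log units; within the scatter) from compound 1 to compound 2 and a 1.9-fold lower number (0.28 log units; within the scatter) from compound 3 to compound 4, 2.8-fold (0.45 log units) apart, beyond the scatter of two such steps. For the compounds shown here, the new step, a 1.9-fold lower number from compound 3 to compound 4 (0.28 log units; within the scatter), lies within the scatter, as does the earlier one, so the gap shows only that the two steps do not match, not that either one is a real change, and a single pair of cores says nothing about other cores. With the 2-hydroxy-2-methylpropyl chain, the large steps remain, a 27-fold higher number from compound 2 to compound 4 (1.44 log units; beyond the scatter) and a 40-fold higher number from compound 1 to compound 4 (1.60 log units; beyond the scatter).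

Open, from the compounds shown here alone, is whether those large steps belong to the hydroxyl itself or to the chain carrying it. A methyl ether or an amine in place of the hydroxyl, or a longer all-carbon chain, would bear on that.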